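The compounds below may be only part of what the source reports. "The series", "measured", "known", "first", "only" and "open" are said of these compounds alone.

Of the compounds shown here, three built on one shared core have been measured in a functional assay on MDA-MB-231 cells (Homo sapiens) for antiproliferative activity, read by XTT assay, with a stated time of 72 h; on this read-out higher numbers stand for weaker inhibition and lower numbers for stronger inhibition. Compound 1 `COc1ccc(-c2cc3ccccc3nc2/C=C/C(=O)c2ccc(F)cc2)cc1` gives 830 nM. Compound 2 `COc1ccc(-c2cc3ccccc3nc2/C=C/C(=O)c2ccc(O)cc2)cc1` gives 6350 nM, and compound 3 `COc1ccc(-c2cc3ccccc3nc2/C=C/C(=O)c2ccc(OC)cc2OC)cc1` gives 3210 nM. Compound 2 thus carries the highest of the three numbers; the nearest is compound 3, with a 2.0-fold lower number from compound 2 to compound 3 (0.30 log units; within the scatter), while the furthest is compound 1, with a 7.7-fold higher number from compound 1 to compound 2 (0.88 log units; beyond the scatter).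

Compound 4 `COc1ccc(-c2cc3ccccc3nc2/C=C/C(=O)c2ccc(Br)s2)cc1` has not yet been measured; it differs from compound 2 by 5-bromothiophen-2-yl in place of 4-hydroxyphenyl on a carbonyl carbon. The step bearing most on this change is a 7.7-fold higher number from compound 1 to compound 2 (0.88 log units; beyond the scatter), where hydroxy in place of fluoro raised the number; a 2.0-fold lower number from compound 2 to compound 3 (0.30 log units; within the scatter) also removed the 4-hydroxyphenyl but stayed within the scatter. A modest fall is therefore expected, about a 5.3-fold lower number from compound 2 to compound 4 (0.72 log units; beyond the scatter). For compound 4 the estimate is 1200 nM, in a range from 400 nM to 3500 nM.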

Compound 4, half-maximal inhibitory concentration: < 100 nM
Compound 4 gave a limit, no number; the forecaster's own chance of this, stated with the estimate: 0%; at least 12-fold (1.07 log units) between middle value and limit.
By their numbers in this assay, from the lowest: compound 1; then compounds 3 and 2 (each within the scatter of the next). At a limit, below all of these: compound 4.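

In this assay compound 4 gave a limit, not a number: the limit of < 100 nM in this assay, at which 1 of the 4 values shown sits.

Swapping the substituents on the phenyl ring at this carbonyl had spanned no more than a 7.7-fold higher number from compound 1 to compound 2 (0.88 log units; beyond the scatter). Leaving the phenyl ring altogether for 5-bromothiophen-2-yl moves the number much further, with an at least 63-fold lower number from compound 2 to compound 4 (1.80 log units; beyond the scatter) and an at least 32-fold lower number from compound 3 to compound 4 (1.50 log units; beyond the scatter), and it still passes the best phenyl compound, with an at least 8.3-fold lower number from compound 1 to compound 4 (0.91 log units; beyond the scatter).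

The compounds shown do not separate the bromine from the thiophene ring, so an unsubstituted thiophen-2-yl or a 5-chlorothiophen-2-yl remains an open case. As far as these compounds go, how far compound 4 lies past its limit also stays open.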